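The source may hold more compounds than are shown below. What is called first, only, known or untested is meant among the compounds shown, and "the series" means these compounds.

Among the measured compounds shown here, in a functional assay on HT-1080 cells (Homo sapiens) for antiproliferative activity, read by MTT assay, with a stated time of 72 h (on this read-out lower numbers stand for stronger inhibition and higher numbers for weaker inhibition), compound 1 `O=C1C=C(N2CCN(c3ccccc3Cl)CC2)C(=O)c2ccccc21` gives 15400 nM and compound 2 `O=C1C=C(N2CCN(c3ccccc3Cl)CC2)C(=O)c2c(O)cccc21` gives 5800 nM as the lower of the two numbers so far. Compound 3 `Cc1ccccc1N1CCN(C2=CC(=O)c3cccc(O)c3C2=O)CC1` differs from compound 2 by methyl in place of chloro on an aromatic carbon with methyl in place of chloro on an aromatic carbon, ortho to a large group. For the measured compounds named here, the only measured step of a 2.7-fold lower number from compound 1 to compound 2 (0.42 log units; beyond the scatter) is modest but is a different change, hydroxy in place of hydrogen on an aromatic carbon, so no measured step speaks to this swap and none beyond the scatter is expected in this assay here. The estimated step is a 1.1-fold higher number from compound 2 to compound 3 (0.05 log units; within the scatter) on this reasoning. Compound 3 is expected at 6500 nM with an estimated range from 2500 nM to 16000 nM for repeated measurements.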

Compound 3, half-maximal inhibitory concentration: 11000 nM
Compound 3: middle estimate off by 1.7-fold (0.23 log units), on the low side; the measured number falls inside the stated range.
By their numbers in this assay, from the lowest: compounds 2, 3 and 1 (each within the scatter of the next, the first and the last beyond it).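

In this assay, methyl in place of chloro on an aromatic carbon, ortho to a large group, gives a 1.9-fold higher number from compound 2 to compound 3 (0.28 log units; within the scatter). This assay therefore does not separate chloro from methyl at this position, something the earlier pair, which differed only in hydroxy, could not show. Nothing available here bears on the cause of this result.

As far as these compounds go, whether methoxy, fluoro or an amine at this position would read apart from chloro and methyl remains open. So does whether methyl and chloro would also read alike on the core of compound 1, without the hydroxy.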